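A few compounds are considered here, and "the series" means these few. Any claim that something is new, unique, unknown or untested is made for them only; others in the source may bear on it.

Measured so far in a physicochemical assay for lipophilicity; on this read-out higher numbers stand for higher lipophilicity and lower numbers for lower lipophilicity:
compound 1, `COc1ccc(-c2[nH]c3ccccc3c2C2=C(Br)C(=O)NC2=O)cc1`, gives 2.42
compound 2, `CCOc1ccc2[nH]c(-c3ccc(OC)cc3)c(C3=C(Br)C(=O)NC3=O)c2c1`, gives 2.77
compound 3, `O=C(CCCc1[nH]c2ccccc2c1C1=C(Br)C(=O)NC1=O)Nc1ccccc1`, gives 2.56

Compound 3 sits within the usual scatter of both compound 1 and compound 2, so among these three no order can be read from its value. The next compound, compound 4, `Cc1cccc(NC(=O)CCCc2[nH]c3ccccc3c2C2=C(Br)C(=O)NC2=O)c1`, differs from compound 3 in one place: methyl in place of hydrogen on an aromatic carbon. Within the data shown here, only one measured step speaks to a change of this kind, namely the addition of a carbon-containing group to an aromatic carbon, and that step, a number 0.35 log units higher from compound 1 to compound 2 (beyond the scatter), was modest but beyond the scatter. A methyl is a smaller addition than an ethoxy, yet it carries no oxygen, so a rise of similar size is expected. For compound 4 the expected step is a number 0.44 log units higher from compound 3 to compound 4 (beyond the scatter) in this assay. Compound 4 is therefore estimated at 3, with a likely range from 2.7 to 3.3.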

Compound 4, partition coefficient: 2.56
Estimate against measurement, compound 4: 0.44 log units above, outside the stated range (below it).
By their numbers in this assay, from the lowest: compounds 1, 3, 4 and 2 (each within the scatter of the next, the first and the last beyond it).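

In this assay, putting methyl in place of hydrogen on an aromatic carbon of the phenylcarbamoyl group, meta to a large group, gives no change at the digits printed from compound 3 to compound 4 (within the scatter). So at this position, this single addition has no readable effect on the read-out, whereas the only earlier step adding a group to an aromatic carbon, a number 0.35 log units higher from compound 1 to compound 2 (beyond the scatter), placed ethoxy on the shared core. Those two steps differ in both the group and its place, so neither factor can be singled out, and nothing measured here explains the contrast.

From the compounds shown here alone, it remains open whether a larger or different group at this same position, such as a longer chain, an amine or a carboxylic acid, would shift the value. Methyl on another carbon of this ring is also an open case.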